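This account rests on a few compounds, and the source may have more. Where it says the series, first, only, none or still open, it means among the compounds named here.

Among the two compounds measured so far, compound 2 `N#Cc1ccc(Cc2cnc(CCc3ccc(-c4ccccc4C(=O)O)cc3)[nH]2)cc1` stands at the highest number: in an in vitro functional assay on cells for agonist activity at Bombesin receptor subtype-3 (Homo sapiens), read by luminescence and calcium flux (a lower number here means that less compound is needed, a higher number that more compound is needed for the effect), compound 2 gives 5890 nM. Its nearest neighbour is compound 1 `O=C(O)c1ccccc1-c1ccc(CCc2ncc(Cc3ccccc3Cl)[nH]2)cc1`, which in this assay gives 292 nM. Among the measured compounds shown here, the single measured step between them, a 20-fold higher number from compound 1 to compound 2 (1.30 log units; beyond the scatter), exchanges both the kind of group and where it sits on the benzyl ring, so it bears on the next change only in part. Compound 3 `O=C(O)c1ccccc1-c1ccc(CCc2ncc(Cc3ccc(Cl)cc3)[nH]2)cc1` is still to be measured. It differs from compound 2 in one place: chloro in place of cyano on an aromatic carbon. Here the group stays para to the large group and only cyano becomes chloro. For the measured compounds named here, since compound 1, the one chlorine-bearing compound, gives the lower number in this assay, a chlorine in compound 3 is expected to lower the number relative to compound 2, though by less than a 20-fold higher number from compound 1 to compound 2 (1.30 log units; beyond the scatter), as that step also moved the group. The estimate for compound 3 in this assay is therefore 1500 nM, with a likely range from 400 nM to 6000 nM, corresponding to an expected step of a 3.9-fold lower number from compound 2 to compound 3 (0.59 log units; beyond the scatter).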

Compound 3, half-maximal effective concentration: 2290 nM
Compound 3: the middle estimate sits 1.5-fold (0.18 log units) below what was measured, and the stated range covers the measured number.
By their numbers in this assay, from the lowest: compound 1; then compound 3; then compound 2.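

With the group held at one place, para to a large group, exchanging cyano for chloro alone gives a 2.6-fold lower number from compound 2 to compound 3 (0.41 log units; beyond the scatter) in this assay, so the identity of the group matters here, though this step is modest. With chlorine kept on the ring, 4-chlorophenyl in place of 2-chlorophenyl gives a 7.8-fold higher number from compound 1 to compound 3 (0.89 log units; beyond the scatter), a wider step than the exchange of cyano for chloro, so the earlier large step from a 20-fold higher number from compound 1 to compound 2 (1.30 log units; beyond the scatter) can now be seen as two parts, with the move of the chlorine accounting for more of it. No measurement here explains either step.

From the compounds shown here alone, the effect of moving a group is known only for chlorine, so it remains open whether a cyano group would show a similar change between the same two places. Going by these compounds, it is also open whether a methoxy group, an amine or a carboxylic acid, placed para to a large group, would give a lower number than chloro, or whether any group there could reach the number of compound 1 at 292 nM.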